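Lengthening the chlorinated chain by one carbon

The source may report more compounds than this note shows. Statements on the series, on what has been measured and on what is new or still open speak of the compounds shown alone.

Compound 1 `O=C(NCCCCl)Nc1ccc(I)cc1` and compound 2 `O=C(CCl)Nc1ccc(I)cc1` share one core and differ only at the carbonyl carbon. In a functional assay on MCF7 cells (Homo sapiens) for antiproliferative activity, with a stated time of 48 h (on this read-out higher numbers stand for weaker inhibition and lower numbers for stronger inhibition), compound 1 gives a limit rather than a number, > 100000 nM. In this assay, going by the values given here, compound 2 gives 6200 nM, the only plain number among the two values shown. Among the compounds with values here, the sole measured step is an at least 16-fold lower number from compound 1 to compound 2 (1.20 log units; beyond the scatter), with compound 1 sitting at the limit of > 100000 nM in this assay, at which 1 of the 2 values shown sits. Compound 3 `O=C(CCCl)Nc1ccc(I)cc1` arises from compound 2 through (chloromethyl in place of chloro on a saturated chain carbon bound to a carbonyl carbon). Within the data shown here, no measured step shows a longer chlorinated chain, so the expectation rests on compound 2 alone and is uncertain. Compound 3 is expected to give 30000 nM, within 8000 nM to 100000 nM. The expected step of a 4.8-fold higher number from compound 2 to compound 3 (0.68 log units; beyond the scatter) points toward weaker inhibition.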

Compound 3, half-maximal inhibitory concentration: 26000 nM
Beside the measured number, compound 3's estimate is 1.2-fold (0.06 log units) above it, and the stated range covers the measured number.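

Lengthening the chlorinated chain from chloromethyl to 2-chloroethyl weakens inhibition in this assay, with a 4.2-fold higher number from compound 2 to compound 3 (0.62 log units; beyond the scatter), so activity at this position depends on chain length. The 2-chloroethyl group still outperforms (3-chloropropyl)amino on the carbonyl carbon, with an at least 3.8-fold lower number from compound 1 to compound 3 (0.58 log units; beyond the scatter). That step gives only a minimum size, because compound 1 sits at a limit: the limit of > 100000 nM in this assay, at which 1 of the 3 values shown sits.

The compounds shown leave open whether a still longer chlorinated chain would weaken inhibition further. They also leave open whether a plain ethyl group, with no chlorine, would keep any activity.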